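Swapping the anilino aryl on a dimethoxyphenyl urea

The compounds below may be only part of what the source reports. "The series", "measured", "known", "first", "only" and "open" are said of these compounds alone.

The series rests on three measured compounds. Compound 1 `COc1cc(NC(=O)Nc2cc(Nc3ccc(C(C)(C)C)cc3)ncn2)cc(OC)c1` gives 32.7% in a functional assay on HCC827 cells (Homo sapiens) for inhibition, read by MTT assay, with a stated time of 48 h, tested at 10 uM (on this read-out higher numbers stand for more inhibition at the one concentration tested (going by the name of the read-out) and lower numbers for less inhibition), the lowest of the three numbers. Compound 2 `COc1ccc(F)cc1Nc1cc(NC(=O)Nc2c(Cl)cccc2Cl)ncn1` gives 78% and compound 3 `Cc1ccc(Nc2cc(NC(=O)Nc3c(Cl)cccc3Cl)ncn2)cc1C` gives 84.3% in the same read-out, both beyond the scatter above compound 1. Compound 4 `COc1cc(NC(=O)Nc2cc(Nc3ccc(C)c(C)c3)ncn2)cc(OC)c1` differs from compound 1 by 3,4-dimethylphenyl in place of 4-(tert-butyl)phenyl on a nitrogen on an aromatic ring. For the measured compounds named here, the one measured step at the same position, a number 6.3 percentage points higher from compound 2 to compound 3 (within the scatter), touches the same nitrogen but exchanges different groups and stays within the scatter, so the data give no sign that this position moves the number much. Compound 4 is therefore expected near compound 1, at 38% with a range of 20% to 60%, a step of a number 5.3 percentage points higher from compound 1 to compound 4 (within the scatter) that is expected to stay within the scatter.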

Compound 4, a percentage reported as inhibition, at one concentration (the size of the read-out at that concentration, not a potency): 45.7%
Compound 4: the middle estimate sits 7.7 percentage points below what was measured, within the range that was stated.
By their numbers in this assay, from the lowest: compound 1; then compound 4; then compounds 2 and 3 (each within the scatter of the next).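

On the core of compound 1, 3,4-dimethylphenyl in place of 4-(tert-butyl)phenyl on the nitrogen gives a number 13 percentage points higher from compound 1 to compound 4 (beyond the scatter), so this position can move the number, a sign the earlier step at this nitrogen did not give. That step involved different groups and stayed within the scatter, so the effect here belongs to this exchange on this core alone. Nothing at hand gives a reason for the rise.

The compounds shown leave open whether the same exchange moves the number on the core of compound 3. They also leave open whether a morpholine or a carboxylic acid on this aryl ring would raise the number further.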